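The source may hold more compounds than are shown below. What is called first, only, known or untested is meant among the compounds shown, and "the series" means these compounds.

Of the compounds shown here, three sharing one core have been measured. Compound 1 `Cc1c(C(=O)N/N=C\c2ccc(O)c(O)c2O)oc2cccc(O)c12`, compound 2 `Cc1c(C(=O)N/N=C\c2cc(Cl)cc(Cl)c2O)oc2cccc(O)c12` and compound 3 `Cc1c(C(=O)N/N=C\c2ccccc2O)oc2cccc(O)c12` differ only in the ring hung from the hydrazone. In a functional assay on MGC-803 cells (Homo sapiens) for inhibition, read by MTT assay (a lower number here means a stronger inhibitor, a higher number a weaker inhibitor), compound 3 gives 10600 nM, the second highest of the three numbers. Its nearest neighbour is compound 1, which in this assay gives 18100 nM, a gap within the scatter, so the two cannot be ranked against each other. Compound 2 stands furthest away: in this assay compound 2 gives 4360 nM, a number beyond the scatter lower than that of compound 3.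

Compound 4 `Cc1c(C(=O)N/N=C\c2ccc(O)cc2O)oc2cccc(O)c12` has not been measured. It differs from compound 3 in one place: hydroxy in place of hydrogen on an aromatic carbon. For the measured compounds named here, no step between measured compounds isolates this change. Compound 1, with its 18100 nM and more hydroxy groups on that ring, sits within the scatter of compound 3, so an added hydroxy is expected to move the number little. For compound 4 the expected step is a 1.2-fold higher number from compound 3 to compound 4 (0.09 log units; within the scatter), in either direction no further than the scatter. Compound 4 is therefore estimated at 13000 nM, with a range from 5000 nM to 35000 nM.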

Compound 4, half-maximal inhibitory concentration: 7330 nM
For compound 4 the middle estimate is 1.8-fold (0.25 log units) above the measured one, within the range that was stated.
By their numbers in this assay, from the lowest: compounds 2, 4, 3 and 1 (each within the scatter of the next, the first and the last beyond it).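

For the compounds shown here, the step of a 1.4-fold lower number from compound 3 to compound 4 (0.16 log units; within the scatter) gives the first direct reading of hydroxy in place of hydrogen at this position, para to a large group, and in this assay it stays within the scatter, so this change does not separate compound 3 from compound 4. The step of a 2.5-fold lower number from compound 1 to compound 4 (0.39 log units; beyond the scatter), hydrogen in place of hydroxy on an aromatic carbon, is modest but lies beyond the scatter, which shows that hydroxy groups on this ring are not all interchangeable in this assay. No measurement offered here explains either step.

On these data alone, whether a methoxy group, an amine or a carboxylic acid at this position would also leave the number within the scatter stays open. So does whether the same hydroxy change would give a similar step on the ring of compound 2.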